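The source may hold more compounds than are shown below. What is called first, only, known or untested is meant among the compounds shown, and "the series" means these compounds.

Compounds measured:
compound 1 `N#C[Se]c1ccc(NC(=O)Oc2ccc(F)cc2)cc1` gives 33300 nM
compound 2 `C=CCOC(=O)Nc1ccc([Se]C#N)cc1` gives 43100 nM

Two compounds share the selenocyanate-bearing core with a carbamate on the ring, and both have been tested in a functional assay on MCF7 cells (Homo sapiens) for cytotoxicity, read by MTT assay, with a stated time of 72 h; on this read-out higher numbers stand for weaker inhibition of growth and lower numbers for stronger inhibition of growth. In this assay compound 1 `N#C[Se]c1ccc(NC(=O)Oc2ccc(F)cc2)cc1` gives 33300 nM. Compound 2 `C=CCOC(=O)Nc1ccc([Se]C#N)cc1` shows the higher of the two numbers, with 43100 nM in this assay, yet its gap to compound 1 lies within the scatter of repeated measurements, so the two values cannot be told apart on the data shown.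

Compound 3 `N#C[Se]c1ccc(NC(=O)OCc2ccccc2)cc1` has not yet been measured. It differs from compound 2 in one place: phenyl in place of vinyl on a saturated chain carbon bound to an oxygen next to a carbonyl group. Among the compounds with values here, no measured pair isolates this kind of change, so there is no step to lean on; what can be said is that the two measured carbamates, one with an aryl ester and one with a short unsaturated chain, sit close together. On that basis the step from compound 2 to compound 3 is expected to be small, a 1.4-fold lower number from compound 2 to compound 3 (0.16 log units; within the scatter), and likely to stay within the scatter. Compound 3 is therefore estimated at 30000 nM, with a range from 10000 nM to 90000 nM.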

Compound 3, concentration for total growth inhibition: 38800 nM
For compound 3 the middle estimate is 1.3-fold (0.11 log units) below the measured one, within the range that was stated.
By their numbers in this assay, from the lowest: compounds 1, 3 and 2 (each within the scatter of the next).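

In this assay, within the data shown here, phenyl in place of vinyl on a saturated chain carbon bound to an oxygen next to a carbonyl group gives a 1.1-fold lower number from compound 2 to compound 3 (0.05 log units; within the scatter) and is the first measured step at this place. The entering group has 6 heavy atoms and one six-membered aromatic ring of carbon only, whereas the leaving group has 2 heavy atoms and one double bond outside aromatic rings, yet compound 2 and compound 3 cannot be told apart. On this one pair, then, the read-out does not distinguish the two groups at this place, and nothing at hand offers an explanation for that result.

From the compounds shown here alone, it remains open whether an amine, a carboxylic acid or a longer chain on the same carbon would give a number that stands beyond the scatter from compound 2 and compound 3. Since every compound shown keeps the selenocyanate group on the shared core, they also leave open what a nitrile or a thiocyanate in its place would give in this assay.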